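Dropping the Aryl Branch: An Expectation for Compound 4

This account rests on a few compounds, and the source may have more. Where it says the series, first, only, none or still open, it means among the compounds named here.

Of the compounds shown here, three built on a shared core have been measured in an assay on isolated protein for inhibition of sterol O-acyltransferase 1 (Mus musculus), tested at 0.1 uM; a higher number here means more inhibition at the concentration tested (going by the name of the read-out), a lower number less inhibition. Compound 1 `CCCCCCCCCCCCn1nnc(C(C(=O)Nc2ccc3c(C)cc(C)nc3n2)c2ccccc2)n1` gives 49%. Compound 2 `CCCCCCCCCCCCn1nnc(C(C(=O)NC(C)(C)C)c2ccccc2)n1` gives 1%, and the step of a number 48 percentage points lower from compound 1 to compound 2 (beyond the scatter) comes from swapping the group on the amide-type nitrogen. Compound 3 `CCCCCCCCCCCCn1nnc(C(C(=O)Nc2c(OC)cc(OC)cc2OC)c2ccc(OC)cc2)n1` gives 61%, the highest of the three numbers, with compound 1 nearest to it and compound 2 furthest from it.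

Compound 4 `CCCCCCCCCCCCn1nnc(CC(=O)Nc2c(OC)cc(OC)cc2OC)n1` differs from compound 3 at one place: hydrogen in place of 4-methoxyphenyl on a saturated chain carbon bound to an aromatic carbon and a carbonyl carbon. Going by the values given here, no measured step touches this position. Among the compounds with values here, the only measured step, from compound 1 to compound 2, alters a different part of the molecule, yet it shows that a single replacement can move the read-out a long way. Taking away a whole aromatic ring is likewise a sizeable change, so a clear fall is expected. Compound 4 is expected to give 22%, within a range of 5% to 45%. That expectation amounts to a step of a number 39 percentage points lower from compound 3 to compound 4 (beyond the scatter).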

Compound 4, a percentage reported as inhibition, at one concentration (the size of the read-out at that concentration, not a potency): 66%
Estimate against measurement, compound 4: 44 percentage points below; measured number above the stated range.
By their numbers in this assay, from the lowest: compound 2; then compound 1; then compounds 3 and 4 (each within the scatter of the next).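

At the saturated chain carbon bound to an aromatic carbon and a carbonyl carbon, hydrogen in place of 4-methoxyphenyl gives a number 5 percentage points higher from compound 3 to compound 4 (within the scatter) in this assay. The earlier compounds shown here showed only that a replacement on the amide-type nitrogen can move this read-out a long way, whereas this first look at the new position shows that removing a whole ring need not do so: with the rest of compound 3 kept, the 4-methoxyphenyl group is not needed to hold the read-out at this level. Nothing available here explains why the read-out holds once the ring has gone.

Going by these compounds, what a methyl group or a hydroxyl group would do on this carbon stays open, as does whether hydrogen would serve equally well with the amide group of compound 1. On these data alone, because each figure is a percentage at one concentration, how the potencies of compound 3 and compound 4 compare also remains open.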